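The source may hold more compounds than are shown below. What is called first, only, known or untested is meant among the compounds shown, and "the series" means these compounds.

Three compounds of the series have so far been run through a functional assay on RPMI 8402 cells (Homo sapiens) for cytotoxicity; a higher number here means a weaker inhibitor, a lower number a stronger inhibitor. Compound 1 `N#Cc1ccc2[nH]c(-c3ccc4[nH]c(-c5ccccc5)nc4c3)nc2c1` carries a cyano group; in this assay compound 1 returns only the limit > 25000 nM. Compound 2 `Cc1cccc(-c2nc3cc(-c4nc5cc(C#N)ccc5[nH]4)ccc3[nH]2)c1` differs from it by a methyl in place of hydrogen on an aromatic carbon and gives 860 nM in this assay. The step of an at least 29-fold lower number from compound 1 to compound 2 (1.46 log units; beyond the scatter) is thus clearly beyond the scatter. Compound 3 `NC(=O)c1ccc2[nH]c(-c3ccc4[nH]c(-c5ccccc5)nc4c3)nc2c1` carries a carbamoyl in place of the cyano; in this assay compound 3 likewise returns only the limit > 25000 nM. The step that the two limits leave unreadable from compound 1 to compound 3, so compound 3 stands at the limit of > 25000 nM in this assay, at which 2 of the 3 values shown sit, with no number of its own. Compound 4 `Cc1cccc(-c2nc3cc(-c4nc5cc(C(N)=O)ccc5[nH]4)ccc3[nH]2)c1` is the unmeasured analog: methyl in place of hydrogen on an aromatic carbon. Among the compounds with values here, the single measured step of the same kind is an at least 29-fold lower number from compound 1 to compound 2 (1.46 log units; beyond the scatter), a large fall in the number. Given that step seen with compound 1, compound 4 is expected to give 1500 nM, between 400 nM and 12000 nM, in this assay. That would mean an estimated step of an at least 16-fold lower number from compound 3 to compound 4 (1.22 log units; beyond the scatter), its size uncertain since the starting point is a limit.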

Compound 4, half-maximal inhibitory concentration: 8200 nM
Estimate against measurement, compound 4: 5.5-fold (0.74 log units) below; the measured number falls inside the stated range.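

The methyl step is not confined to the nitrile compounds: phenyl to 3-methylphenyl also gives an at least 3.0-fold lower number from compound 3 to compound 4 (0.48 log units; beyond the scatter) in this assay on the carbamoyl side. With the methyl present, the change from cyano to carbamoyl can now be sized, as a 9.5-fold higher number from compound 2 to compound 4 (0.98 log units; beyond the scatter) in this assay, whereas the step between the pair without the methyl cannot be read. The methyl step is therefore seen on both cores, but its size on the two cannot be compared: the same change on two cores in this assay, an at least 29-fold lower number (1.46 log units; beyond the scatter) from compound 1 to compound 2 and an at least 3.0-fold lower number (0.48 log units; beyond the scatter) from compound 3 to compound 4; the limit leaves it open whether they differ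

From the compounds shown here alone, whether a larger group, such as ethyl or an amine, on the same aromatic carbon would carry the same fall in the number remains open. So does the outcome of replacing the cyano with a carboxylic acid, on either the phenyl or the 3-methylphenyl compounds.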